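The source may report more compounds than this note shows. Statements on the series, on what has been measured and on what is new or still open speak of the compounds shown alone.

Compound 1 `FC(F)(F)c1cccc(-c2nc3cnc(Nc4ccccn4)cc3[nH]2)c1`. In a physicochemical assay for solubility, using the shake flask method, in phosphate buffer, measured as kinetic solubility, with a stated time of 20 h, at pH 6.5 (on this read-out higher numbers stand for higher solubility and lower numbers for lower solubility), compound 1 gives < 5000 nM, which is a limit of the assay rather than a number.
Compound 2 `Fc1ccc(Nc2cc3[nH]c(-c4cccc(C(F)(F)F)c4)nc3cn2)nc1`. In this assay compound 2 gives < 5000 nM, again a limit.

Compound 2 therefore stands at the limit of < 5000 nM in this assay, at which 2 of the 2 values shown sit, with only a limit and no exact number. Among the compounds with values here, the one measured step, a step that the two limits leave unreadable from compound 1 to compound 2, cannot be sized. Compound 3 `O=C(O)c1ccnc(Nc2cc3[nH]c(-c4cccc(C(F)(F)F)c4)nc3cn2)c1` differs from compound 2 by 4-carboxypyridin-2-yl in place of 5-fluoropyridin-2-yl on a nitrogen on an aromatic ring. Within the data shown here, no measured step resembles this change, so the expectation is rough. For compound 3 an upward step an at least 6.0-fold higher number from compound 2 to compound 3 (0.77 log units; beyond the scatter) is expected. The estimated value for compound 3 is 30000 nM, within a range from 3000 nM to 200000 nM.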

Compound 3, solubility: < 5000 nM
Compound 3: only a limit was reported (the forecaster's own chance of this, stated with the estimate: 30%); middle value at least 6.0-fold (0.77 log units) away from the limit.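

Within the data shown here, compound 1, compound 2 and compound 3 all sit at a limit rather than a number in this assay, so no step between them can be read: the limit of < 5000 nM in this assay, at which 3 of the 3 values shown sit. From the compounds shown here alone, the actual values of all three, and whether 4-carboxypyridin-2-yl in place of 5-fluoropyridin-2-yl changes them at all, stay open.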